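The compounds below may be only part of what the source reports. "The series", "measured", "known", "first", "only" and "open" are said of these compounds alone.

In an assay on microsomes from brain for inhibition of Fatty-acid amide hydrolase 1 (Rattus norvegicus), read by fluorescence and HPLC, with a stated time of 60 min (on this read-out higher numbers stand for weaker inhibition and lower numbers for stronger inhibition), compound 1 `CCCCCCCCc1ccc(OCC(=O)Cn2nnnc2C)cc1` gives 41 nM. Compound 2 `CCCCCCCCc1ccc(OCC(=O)Cn2nnnc2-c2ccc(Cl)cc2)cc1` gives 130 nM, and compound 3 `CCCCCCCCc1ccc(OCC(=O)Cn2nnnc2-c2cccc(Cl)c2)cc1` gives 360 nM, the highest of the three numbers, as the steps of an 8.8-fold higher number from compound 1 to compound 3 (0.94 log units; beyond the scatter) and a 2.8-fold higher number from compound 2 to compound 3 (0.44 log units; beyond the scatter) show. Compound 4 `CCCCCCCCc1ccc(OCC(=O)Cn2nnnc2-c2cccc(S(=O)(=O)N(C)C)c2)cc1` differs from compound 3 by dimethylsulfamoyl in place of chloro on an aromatic carbon. For the measured compounds named here, no measured step swaps one group for another on this phenyl ring. The steps of a 3.2-fold higher number from compound 1 to compound 2 (0.50 log units; beyond the scatter) and an 8.8-fold higher number from compound 1 to compound 3 (0.94 log units; beyond the scatter) only show that moving from methyl to a chlorophenyl group raises the number, and the step between compound 2 and compound 3 shows that where the chloro sits on that ring also matters. On this guide, a further modest rise for compound 4, or no change beyond the scatter, is expected, a 1.7-fold higher number from compound 3 to compound 4 (0.22 log units; within the scatter). Compound 4 is therefore estimated at 600 nM, within a range from 150 nM to 2500 nM.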

Compound 4, half-maximal inhibitory concentration: 1900 nM
Compound 4: the middle estimate sits 3.2-fold (0.50 log units) below what was measured; the range from low to high includes it.
By their numbers in this assay, from the lowest: compound 1; then compound 2; then compound 3; then compound 4.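

In this assay, for the compounds shown here, the swap of chloro for dimethylsulfamoyl on the phenyl ring gives a 5.3-fold higher number from compound 3 to compound 4 (0.72 log units; beyond the scatter), the first measured exchange of one group for another at this place, so the group held there matters and not only where a chloro sits. The gaps to the other compounds grow to a 15-fold higher number from compound 2 to compound 4 (1.16 log units; beyond the scatter) and a 46-fold higher number from compound 1 to compound 4 (1.67 log units; beyond the scatter), leaving compound 4 with the highest number of the four. No measurement at hand explains this rise. As far as these compounds go, whether an amine or a carboxylic acid at this place would lower the number stays open. So does whether dimethylsulfamoyl would act alike where compound 2 carries its chloro.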